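This account rests on a few compounds, and the source may have more. Where it says the series, first, only, none or still open, it means among the compounds named here.

In a functional assay on MCF7 cells (Homo sapiens) for inhibition, read by MTT assay, with a stated time of 72 h (a higher number here means a weaker inhibitor, a lower number a stronger inhibitor), compound 1 `O=C(Nc1ccccc1)C1CCN(C/C=C/c2ccccc2)CC1` gives 60200 nM, compound 2 `CC(C)c1ccc(NC(=O)C2CCN(C/C=C/c3ccccc3)CC2)cc1` gives 9100 nM and compound 3 `O=C(Nc1cccc(F)c1)C1CCN(C/C=C/c2ccccc2)CC1` gives 33000 nM. Compound 3 stands level with compound 1, given the step of a 1.8-fold lower number from compound 1 to compound 3 (0.26 log units; within the scatter), and clearly apart from compound 2, given the step of a 3.6-fold higher number from compound 2 to compound 3 (0.56 log units; beyond the scatter). Compound 4 `O=C(Nc1cccc(Br)c1)C1CCN(C/C=C/c2ccccc2)CC1` has bromo in place of fluoro on an aromatic carbon. Within the data shown here, no measured step swaps one of these groups for the other. The nearest guides are the fluoro step above and the isopropyl step of a 6.6-fold lower number from compound 1 to compound 2 (0.82 log units; beyond the scatter). Together they suggest a small move towards a lower number in this assay, probably within the scatter. The expected change is a 1.5-fold lower number from compound 3 to compound 4 (0.18 log units; within the scatter). Compound 4 is estimated at 22000 nM, with an expected range of 10000 nM to 48000 nM.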

Compound 4, half-maximal inhibitory concentration: 11500 nM
Beside the measured number, compound 4's estimate is 1.9-fold (0.28 log units) above it, within the range that was stated.
By their numbers in this assay, from the lowest: compounds 2 and 4 (each within the scatter of the next); then compounds 3 and 1 (each within the scatter of the next).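

In this assay the choice of halogen matters at this position: swapping fluoro for bromo gives a 2.9-fold lower number from compound 3 to compound 4 (0.46 log units; beyond the scatter) and so separates two groups that a single halogen step might have suggested were alike. Fluoro made no clear difference from hydrogen, whereas bromo does, with a 5.2-fold lower number from compound 1 to compound 4 (0.72 log units; beyond the scatter) as the step. Changing the aryl group gives a 1.3-fold higher number from compound 2 to compound 4 (0.10 log units; within the scatter) and leaves 3-bromophenyl level with 4-isopropylphenyl. No measurement here explains why bromo differs from fluoro. As far as these compounds go, whether chloro, iodo, methoxy or an amine at this position would follow bromo or fluoro remains open.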